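Swapping a Phenyl for a Bicyclic Ring on the Core

The compounds below may be only part of what the source reports. "The series", "measured", "known", "first", "only" and "open" are said of these compounds alone.

In a physicochemical assay for lipophilicity, read by HPLC (on this read-out higher numbers stand for higher lipophilicity and lower numbers for lower lipophilicity), compound 2 `N#Cc1cnc(-c2ccccc2)nc1N1C[C@@H]2C[C@H]1CN2c1cccc(F)c1` gives 4.5, the highest of the three measured numbers. Compound 1 `C[C@@H]1CN(c2nc(-c3cnn(C)c3)ncc2C#N)CCN1c1cccc(F)c1` gives 3.3 and compound 3 `C[C@@H]1C[C@H]1C(=O)N1CCN(c2nc(-c3cnn(C)c3)ncc2C#N)C[C@H]1C` gives 1.9. Among the compounds with values here, the single measured step, a number 1.40 log units lower from compound 1 to compound 3 (beyond the scatter), exchanges a 3-fluorophenyl on an amine nitrogen in a ring for a (2-methylcyclopropyl)carbonyl. That change sits at a different place from the one considered here, so it only shows that replacing a carbon-only ring with a group carrying hetero atoms can move this assay a great deal. Compound 4 `N#Cc1cnc(-c2ccnc3[nH]ccc23)nc1N1C[C@@H]2C[C@H]1CN2c1cccc(F)c1` differs from compound 2 by a group of 9 heavy atoms (7 carbon, 2 nitrogen; one five-membered aromatic ring with 1 hetero atom, one six-membered aromatic ring with 1 hetero atom) in place of a group of 6 heavy atoms (6 carbon; one six-membered aromatic ring of carbon only), on an aromatic carbon. Since the entering group counts 1 hydrogen-bond donor and 1 hydrogen-bond acceptor where phenyl counts none, a downward step is expected: a number 1.00 log units lower from compound 2 to compound 4 (beyond the scatter). Compound 4 is therefore estimated at 3.5, between 2.8 and 4.2.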

Compound 4, distribution coefficient: 3.4
Compound 4: middle estimate off by 0.10 log units, on the high side, and the stated range covers the measured number.
By their numbers in this assay, from the lowest: compound 3; then compounds 1 and 4 (each within the scatter of the next); then compound 2.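

Within the data shown here, the step at this aromatic carbon, between two ring nitrogen atoms, is the first measured here at this position: in this assay, the entering group gives a number 1.10 log units lower from compound 2 to compound 4 (beyond the scatter). So the number can fall at this position even when the entering group has more heavy atoms than phenyl. No measurement available here explains the fall.

Still open, as far as these compounds go, is how a plain pyridine ring, or a phenyl carrying an amine, would read at this position. That leaves unsettled how much of the step belongs to the five-membered ring and how much to the six-membered ring.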